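Fluoro to ethyl on the arylsulfanyl arm of compound 1

A few compounds are considered here, and "the series" means these few. Any claim that something is new, unique, unknown or untested is made for them only; others in the source may bear on it.

Two members of the series carry numbers. Compound 1 `Nc1ccccc1NC(=O)/C=C/c1ccc(CSc2ccc(F)cc2)cc1` is examined in a functional assay on HCT-116 cells (Homo sapiens) for inhibition, read by CCK-8 assay, with a stated time of 72 h, tested at 2 uM (on this read-out higher numbers stand for more inhibition of growth at the one concentration tested and lower numbers for less inhibition of growth), where compound 1 gives 14.1%. Going by the values given here, compound 2 `COc1ccc(SCc2ccc(C(=O)Nc3ccccc3N)cc2)cc1` differs from compound 1 in more than one place, so no single step joins them; in this assay compound 2 gives 73.3%, a number beyond the scatter above that of compound 1. On the numbers in hand compound 1 stands lowest of the two.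

Compound 3 `CCc1ccc(SCc2ccc(/C=C/C(=O)Nc3ccccc3N)cc2)cc1` awaits measurement. It differs from compound 1 by ethyl in place of fluoro on an aromatic carbon, which at one bond further out reads 4-fluorophenyl to 4-ethylphenyl on the sulfanyl arm. Among the compounds with values here, no measured pair isolates this exchange, and the gap between compound 1 and compound 2 cannot be read as a single change. The step from compound 1 to compound 3 in this assay is therefore expected to be small and upward, a number 9.9 percentage points higher from compound 1 to compound 3 (within the scatter), probably within the usual scatter. For compound 3 in this assay the expected value is 24%, with a range from 5% to 55%.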

Compound 3, percent growth inhibition at one concentration: 3.29%
Estimate against measurement, compound 3: 20.7 percentage points above; the whole stated range lies above it.
By their numbers in this assay, from the lowest: compound 3; then compound 1; then compound 2.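

In this assay, going by these compounds alone, the exchange of fluoro for ethyl on the sulfanyl arm gives the first single-place reading at this position, a number 10.8 percentage points lower from compound 1 to compound 3 (beyond the scatter), so the change from 4-fluorophenyl to 4-ethylphenyl does register, modest as the step is, and it runs downward. The exchange adds one heavy atom and no hydrogen-bond donor or acceptor, and both compounds rest on a reading at a single concentration, so the step describes growth inhibition at that concentration and not a full concentration response. Nothing in hand accounts for this step.

Steps from compound 2 to compound 1 or compound 3 cannot be read, since compound 2 differs from each in more than one place, and the series therefore does not show how this exchange behaves on the core of compound 2. Also open, on these data alone, is how the number moves with other groups at this same aromatic carbon, such as an amine, a carboxylic acid or a longer chain like butyl, since two groups at one place give a single step and no trend.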